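Working notes: from compound 2 to compound 3

A few compounds are considered here, and "the series" means these few. Any claim that something is new, unique, unknown or untested is made for them only; others in the source may bear on it.

Measured so far:
compound 1 `COc1ccc(/C=C/c2c(CC=C(C)C)c(O)cc3c2CCC(C)(C)O3)cc1O`: "not active" (no number reported)
compound 2 `CC(C)=CCc1c(O)cc(O)c(CC=C(C)C)c1/C=C/c1ccc(O)cc1`: 900 nM

Going by the values given here, in an assay on isolated protein for inhibition of Polyunsaturated fatty acid 5-lipoxygenase (Homo sapiens), read by ELISA (on this read-out lower numbers stand for stronger inhibition and higher numbers for weaker inhibition), compound 2 gives 900 nM and is the only compound with a number; compound 1 is reported as "not active" (no number reported) without a number. Compound 3 `COc1ccc(/C=C/c2c(CC=C(C)C)c(O)cc(O)c2CC=C(C)C)cc1` differs from compound 2 by methyl in place of hydrogen on an oxygen on an aromatic ring. Among the compounds with values here, no step between measured compounds exists, so the size of this change is untested; compound 1, which also carries a methoxy but differs in further places, is not active. A step toward weaker inhibition, beyond the scatter, is expected. Compound 3 is expected at 2500 nM, ranging from 900 nM to 7000 nM. The expected step is a 2.8-fold higher number from compound 2 to compound 3 (0.44 log units; beyond the scatter).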

Compound 3, half-maximal inhibitory concentration: 1100 nM
The estimate for compound 3 lay 2.3-fold (0.36 log units) above the measured number; low and high end bracket the measured number.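

In this assay, the hydroxy to methoxy change on the 4-hydroxyphenyl gives a 1.2-fold higher number from compound 2 to compound 3 (0.09 log units; within the scatter) as a single-place comparison. The hydrogen on this oxygen is therefore not required to retain the inhibition seen with compound 2, and methyl is tolerated here. No measured evidence bears on this result.

The compounds shown leave open how a longer chain on this oxygen or an amine in place of the hydroxy would read. Going by these compounds, the same methyl change on the other aromatic hydroxy groups also remains open.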